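Replacing fluoro with methoxy on compound 3

A few compounds are considered here, and "the series" means these few. Any claim that something is new, unique, unknown or untested is made for them only; others in the source may bear on it.

Values in a functional assay on V79 cells (Cricetulus griseus) for cytotoxicity, read by colony formation; a higher number here means a weaker inhibitor, a lower number a stronger inhibitor:
- Compound 1 `COc1c(N2CCC(N)C2)c(F)cc2c(=O)c(C(=O)O)cn(C3CC3)c12`: 45 ug/mL; 44 ug/mL; 45 ug/mL (3 entries)
- Compound 2 `CC1CN(c2cc3c(cc2F)c(=O)c(C(=O)O)cn3C2CC2)CC(C)N1`: > 500 ug/mL, a limit of the assay
- Compound 3 `CC1CN(c2c(F)cc3c(=O)c(C(=O)O)cn(C4CC4)c3c2F)CC(C)N1`: 150 ug/mL

In this assay compound 3 gives 150 ug/mL, a higher number than compound 1 at 45 ug/mL; 44 ug/mL; 45 ug/mL (3 entries). Compound 2 stands at a limit of the assay, > 500 ug/mL.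

Compound 4 `COc1c(N2CC(C)NC(C)C2)c(F)cc2c(=O)c(C(=O)O)cn(C3CC3)c12` carries methoxy in place of fluoro on an aromatic carbon, ortho to a 3,5-dimethylpiperazin-1-yl group: methoxy in place of fluoro on an aromatic carbon.

For the measured compounds named here, one measured step bears on this change: an at least 3.3-fold lower number from compound 2 to compound 3 (0.52 log units; beyond the scatter), where fluoro replaced hydrogen. That step lies beyond the scatter, but it starts from a limit and does not test methoxy. Compound 1 does carry methoxy and gives 45 ug/mL; 44 ug/mL; 45 ug/mL (3 entries), but it lacks the 3,5-dimethylpiperazin-1-yl group, so it offers only a loose hint towards a lower number. Going by the values given here, no measured pair compares methoxy with fluoro directly. A change beyond the scatter in this assay is therefore not expected, and the estimated step is a 1.2-fold lower number from compound 3 to compound 4 (0.06 log units; within the scatter). For compound 4 the estimated value is 130 ug/mL, with an expected range from 55 ug/mL to 320 ug/mL.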

Compound 4, half-maximal inhibitory concentration: > 500 ug/mL
Compound 4: only a limit was reported; the forecaster's own chance of this, stated with the estimate: 15%; middle value at least 3.8-fold (0.58 log units) from the limit.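

In this assay, methoxy in place of fluoro, ortho to a 3,5-dimethylpiperazin-1-yl group, gives an at least 3.3-fold higher number from compound 3 to compound 4 (0.52 log units; beyond the scatter). Compound 2, with hydrogen at this place, and compound 4, with methoxy, both stand at a limit of the assay, so the step between them cannot be read, and among these three compounds only compound 3, with fluoro, gives a number that is not a limit: the limit of > 500 ug/mL in this assay, at which 2 of the 4 values shown sit.

Methoxy does not bring a low number on its own either: compound 1 also carries methoxy, lacks the 3,5-dimethylpiperazin-1-yl group and gives 45 ug/mL; 44 ug/mL; 45 ug/mL (3 entries).

The compounds shown leave open the full size of the step to compound 4, and whether hydrogen and methoxy differ at all at this place when the 3,5-dimethylpiperazin-1-yl group is present. They also leave open how chloro, ethoxy or an amine at this place, with that same group ortho to it, would read in this assay.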